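The source may hold more compounds than are shown below. What is called first, only, known or untested is meant among the compounds shown, and "the series" means these compounds.

Values from a functional assay on PC-3 cells (Homo sapiens) for inhibition, read by MTT assay, with a stated time of 48 h, tested at 10 uM (on this read-out lower numbers stand for less inhibition of growth and higher numbers for more inhibition of growth at the one concentration tested), so far stand as follows
compound 1 `Cc1cc(=O)c2c(O)c(CN3CCC(Cc4ccccc4)CC3)c(O)c([C@H]3CCN(C)C[C@H]3O)c2o1` gives 16% 
compound 2 `Cc1cc(=O)c2c(O)c(CN(C)CC(=O)O)c(O)c([C@H]3CCN(C)C[C@H]3O)c2o1` gives 20% 

Compound 2 stands at 20% and compound 1 at 16% on this read-out, two numbers within the scatter of each other.

Compound 3 `Cc1cc(=O)c2c(O)c(CN3CCCCC3)c(O)c([C@H]3CCN(C)C[C@H]3O)c2o1` has not yet been measured. It keeps the shared core of compound 2 and takes piperidin-1-yl in place of (carboxymethyl)(methyl)amino on a saturated chain carbon bound to an aromatic carbon.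

Within the data shown here, no measured pair in this assay shows this change directly. Compound 1, which also holds a six-membered non-aromatic ring on that chain carbon, gives 16% and compound 2, with no ring there, gives 20% in the same test, so the ring alone offers no reason to expect movement. The expected move is a number 2 percentage points higher from compound 2 to compound 3 (within the scatter) and stays within the scatter, in no firm direction, though two compounds are thin evidence. For compound 3 the estimated value is 22% with an expected range from 8% to 40% in this test.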

Compound 3, percent growth inhibition at one concentration: 14%
The estimate for compound 3 lay 8 percentage points above the measured number; low and high end bracket the measured number.
By their numbers in this assay, from the lowest: compounds 3, 1 and 2 (each within the scatter of the next).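

In this assay, the exchange of (carboxymethyl)(methyl)amino for piperidin-1-yl on a saturated chain carbon bound to an aromatic carbon can now be read directly as a number 6 percentage points lower from compound 2 to compound 3 (within the scatter) and so shows no clear effect of replacing this open group with a ring at this place. The new compound also separates the benzyl group from the ring that carries it: hydrogen in place of benzyl on a saturated ring carbon gives a number 2 percentage points lower from compound 1 to compound 3 (within the scatter) and leaves no readable effect of the benzyl group in this test. Neither change therefore moves the number beyond the scatter, and the three groups at this place cannot be ranked on this read-out.

On these data alone, it remains open whether a different amine on this chain carbon, such as morpholin-4-yl or dimethylamino, or a longer chain ending in a carboxylic acid, would give a number beyond the scatter of these three. No measurement shown here offers an explanation for these results.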